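The compounds below may be only part of what the source reports. "The series", "measured", "known", "first", "only" and "open" are said of these compounds alone.

Measured so far in an assay on isolated protein for inhibition of legumain (Homo sapiens), with stated times of 2 min and 60 min; a higher number here means a weaker inhibitor, a lower number a stronger inhibitor:
compound 1 `CC(C)CS(=O)(=O)N(Cc1ccc(-c2cccc(F)c2F)cc1)[C@@H](C)C(=O)N[C@H](C#N)CC(N)=O` gives 1820 nM
compound 2 `CC(C)CS(=O)(=O)N(Cc1ccc(-c2cccc(F)c2)cc1)[C@@H](C)C(=O)N[C@H](C#N)CC(N)=O` gives 2270 nM
compound 3 `CS(=O)(=O)N(CC(=O)N[C@H](C#N)CC(N)=O)Cc1ccc(-c2cccc(F)c2)cc1` gives > 10000 nM, which is a limit of the assay and not a number.

Compound 2 has the higher of the two numbers that are numbers, with compound 1 nearest; the step of a 1.2-fold higher number from compound 1 to compound 2 (0.10 log units; within the scatter) lies within the scatter, so no order between compound 1 and compound 2 follows from it. Among the measured compounds shown here, compound 3 differs from compound 2 in more than one place and gives only a limit (the limit of > 10000 nM in this assay, at which 1 of the 3 values shown sits), so it yields no step of its own.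

Compound 4 `CCS(=O)(=O)N(Cc1ccc(-c2cccc(F)c2)cc1)[C@@H](C)C(=O)N[C@H](C#N)CC(N)=O` is compound 2 with methyl in place of isopropyl on a saturated chain carbon bound to a sulfonyl sulfur. No measured step touches the sulfonyl chain: the one step shown, a 1.2-fold higher number from compound 1 to compound 2 (0.10 log units; within the scatter), concerns a fluoro on an aromatic carbon and is within the scatter, so it gives no guide to the size of this change. With nothing to anchor it, the expected step of a 1.5-fold higher number from compound 2 to compound 4 (0.19 log units; within the scatter) in this assay is taken as a moderate move toward a higher number, of a size near the edge of the scatter. Compound 4 is therefore estimated at 3500 nM, with a range from 1500 nM to 9000 nM.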

Compound 4, half-maximal inhibitory concentration: 3890 nM
Beside the measured number, compound 4's estimate is 1.1-fold (0.05 log units) below it; measured number inside the range.
By their numbers in this assay, from the lowest: compounds 1, 2 and 4 (each within the scatter of the next, the first and the last beyond it). At a limit, above all of these: compound 3.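

The sulfonyl chain now has a step of its own in this assay, with methyl in place of isopropyl on a saturated chain carbon bound to a sulfonyl sulfur giving a 1.7-fold higher number from compound 2 to compound 4 (0.23 log units; within the scatter). No order between the isobutylsulfonyl and ethylsulfonyl compounds follows from this step, so the two chains cannot be told apart at this position in this assay. Nothing shown bears on the cause of this step.

Still open, as far as these compounds go, is whether an amine, a carboxylic acid or a longer chain such as n-hexyl in this position would shift the number beyond the scatter. Also open, from the compounds shown here alone, is whether the same change from isobutyl to ethyl would give a similar step on compound 1.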